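Sulfamate series: amine substituent swap from compound 2 to compound 3

The source may hold more compounds than are shown below. What is called first, only, known or untested is meant among the compounds shown, and "the series" means these compounds.

Compound 2 `CN(CCCN1CCCCC1)c1cccc(C(=O)N2CCc3ccc(OS(N)(=O)=O)cc3C2)c1` gives 24.1% in an assay on HEK293 cells for inhibition of Steryl-sulfatase (Homo sapiens), tested at 0.1 uM; on this read-out higher numbers stand for a stronger effect at the one concentration tested and lower numbers for a weaker effect; compound 1 `CCN(Cc1ccncc1)c1cccc(C(=O)N2CCc3ccc(OS(N)(=O)=O)cc3C2)c1` gives 33.3%, and the two lie within the scatter of each other, as shown by a number 9.2 percentage points lower from compound 1 to compound 2 (within the scatter). Compound 3 `CCCN(Cc1ccccc1)c1cccc(C(=O)N2CCc3ccc(OS(N)(=O)=O)cc3C2)c1` differs from compound 2 by benzyl(propyl)amino in place of methyl(3-(piperidin-1-yl)propyl)amino on an aromatic carbon. Within the data shown here, the only measured step, from compound 1 to compound 2, concerns the same position and stayed within the scatter, so no move beyond the scatter is expected here either: the step of a number 5.9 percentage points higher from compound 2 to compound 3 (within the scatter) is an estimate. For compound 3 the expected read-out is 30%, in the range 12% to 50%.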

Compound 3, a percentage reported as inhibition, at one concentration (the size of the read-out at that concentration, not a potency): 23.1%
Estimate against measurement, compound 3: 6.9 percentage points above; the range from low to high includes it.
By their numbers in this assay, from the lowest: compounds 3, 2 and 1 (each within the scatter of the next, the first and the last beyond it).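

In this assay, a benzyl(propyl)amino group in place of methyl(3-(piperidin-1-yl)propyl)amino leaves the read-out unmoved (a number 1 percentage points lower from compound 2 to compound 3 (within the scatter)), so at this position the six-membered non-aromatic ring and the aromatic carbon ring are not told apart. Against ethyl((pyridin-4-yl)methyl)amino, the same benzyl(propyl)amino group gives the first modest step here that lies beyond the scatter (a number 10.2 percentage points lower from compound 1 to compound 3 (beyond the scatter)). No measurement on hand explains either step.

From the compounds shown here alone, compounds 1 and 3 differ in both the ring and the alkyl chain, so which of the two carries the gap stays open. Benzyl(ethyl)amino would separate them.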